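A few compounds are considered here, and "the series" means these few. Any claim that something is new, unique, unknown or untested is made for them only; others in the source may bear on it.

Three compounds share one core and differ only in the group on a carbonyl carbon. Compound 1 `CCCC(=O)Nc1cccc(NC(=O)COc2ccc3c(=O)ccoc3c2)c1` carries a propyl group there, and in an assay on isolated protein for inhibition of Rho-associated protein kinase 2 (Homo sapiens), read by scintillation counting, radiometric assay and 33P incorporation, with a stated time of 40 min, in the presence of a further agent that is not named here (on this read-out higher numbers stand for weaker inhibition and lower numbers for stronger inhibition), compound 1 gives 176 nM. Compound 2 `O=C(COc1ccc2c(=O)ccoc2c1)Nc1cccc(NC(=O)c2ccc(Br)cc2)c1` carries a 4-bromophenyl group, and in this assay compound 2 gives 49 nM. Compound 3 `O=C(COc1ccc2c(=O)ccoc2c1)Nc1cccc(NC(=O)c2ccc(OC(F)(F)F)cc2)c1` carries a 4-(trifluoromethoxy)phenyl group, and in this assay compound 3 gives 77 nM. Compound 3 thus stands second highest of the three numbers: a 1.6-fold higher number from compound 2 to compound 3 (0.20 log units; within the scatter), which is within the scatter, whereas a 2.3-fold lower number from compound 1 to compound 3 (0.36 log units; beyond the scatter), which is beyond it.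

Compound 4 `Cc1nc(C(=O)Nc2cccc(NC(=O)COc3ccc4c(=O)ccoc4c3)c2)cs1` differs from compound 3 in one place: 2-methyl-1,3-thiazol-4-yl in place of 4-(trifluoromethoxy)phenyl on a carbonyl carbon. Going by the values given here, the steps that bear on this are a 3.6-fold lower number from compound 1 to compound 2 (0.56 log units; beyond the scatter) and a 2.3-fold lower number from compound 1 to compound 3 (0.36 log units; beyond the scatter), both modest gains when an aromatic ring replaced the propyl chain, while a 1.6-fold higher number from compound 2 to compound 3 (0.20 log units; within the scatter) shows the two aromatic variants close together. Compound 4 keeps an aromatic ring, now a five-membered one with 2 hetero atoms, so for compound 4 the expected step is a 1.4-fold higher number from compound 3 to compound 4 (0.15 log units; within the scatter), with no clear direction beyond the scatter. For compound 4 the estimate in this assay is 110 nM, ranging from 40 nM to 300 nM.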

Compound 4, half-maximal inhibitory concentration: 33 nM
For compound 4 the middle estimate is 3.3-fold (0.52 log units) above the measured one; the whole stated range lies above it.
By their numbers in this assay, from the lowest: compounds 4, 2 and 3 (each within the scatter of the next, the first and the last beyond it); then compound 1.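

The position on the carbonyl carbon does not depend on a six-membered ring of carbon only: in this assay, 2-methyl-1,3-thiazol-4-yl in place of 4-(trifluoromethoxy)phenyl gives a 2.3-fold lower number from compound 3 to compound 4 (0.37 log units; beyond the scatter), a modest gain from a group with fewer heavy atoms. The same ring in place of 4-bromophenyl gives a 1.5-fold lower number from compound 2 to compound 4 (0.17 log units; within the scatter), so those two groups cannot be told apart here, while in place of propyl it gives a 5.3-fold lower number from compound 1 to compound 4 (0.73 log units; beyond the scatter), which confirms that all three aromatic groups shown beat the propyl chain. No measurement given here accounts for these steps.

With a single five-membered ring shown, the share of its methyl group and of its two hetero atoms cannot be separated. From the compounds shown here alone, how an unsubstituted thiazole, a furan, a pyridine or an amine such as piperidine would fare at this carbonyl carbon remains open.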